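Methyl for Hydrogen on the Core of Compound 2

The source may hold more compounds than are shown below. What is called first, only, known or untested is meant among the compounds shown, and "the series" means these compounds.

This account follows a single change on a coumarin-free basis: the shared core is simply described by its structures. Compound 2 `O=C(CCCCC1CCSS1)NCc1cn(CCCCCOc2ccc3ccc(=O)oc3c2)nn1` was tested in a functional assay on PC-12 cells (Rattus norvegicus) for cytotoxicity, read by MTT assay, with stated times of 3 h and 2 h, tested at 20 uM (a higher number here means a stronger effect of the compound at the concentration tested, a lower number a weaker effect), where compound 2 gives 78.5%. Of the two numbers measured, compound 2 stands highest; its nearest neighbour, compound 1 `O=C(CCCCC1CCSS1)NCc1cn(CCCCOc2ccc3cc(-c4ccccc4)c(=O)oc3c2)nn1`, gives 26% in this assay, a gap that lies beyond the scatter. Within the data shown here, no step between compounds differing in one place has been measured, so the pair shows only what its two values show.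

Compound 3 `Cc1cc(=O)oc2cc(OCCCCCn3cc(CNC(=O)CCCCC4CCSS4)nn3)ccc12` has not yet been measured in this assay. It differs from compound 2 by methyl in place of hydrogen on an aromatic carbon, a methyl on an aromatic carbon of the six-membered aromatic ring with one oxygen, ortho to a fused ring.

A small change of this kind is expected to give a step of a number 6.5 percentage points lower from compound 2 to compound 3 (within the scatter) that is not beyond the scatter in either direction. Compound 3 is therefore estimated at 72%, in a range from 50% to 90%.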

Compound 3, a percentage reported as activity, at one concentration (the size of the read-out at that concentration, not a potency): 70.3%
Compound 3: middle estimate off by 1.7 percentage points, on the high side, within the range that was stated.
By their numbers in this assay, from the lowest: compound 1; then compounds 3 and 2 (each within the scatter of the next).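

With methyl in place of hydrogen on an aromatic carbon, the read-out in this assay shows a number 8.2 percentage points lower from compound 2 to compound 3 (within the scatter). This is the only single-place step among the compounds shown, and it gives the first direct reading of this position, opposite the ring oxygen: here, the read-outs for hydrogen and methyl cannot be told apart. Nothing available offers an explanation for this step.

On these data alone, a single methyl says little about how this position would respond to a different group, so it remains open whether an amine, a carboxylic acid or a longer chain in the same place would also stay within the scatter of compound 2 or move clearly away from it. Because each read-out comes from one concentration, the step also leaves open how the two compounds would compare at other concentrations.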